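Removing an aromatic methyl group from a piperidinol amide

The source may report more compounds than this note shows. Statements on the series, on what has been measured and on what is new or still open speak of the compounds shown alone.

Compound 1: `CCC1(O)CCN(C(=O)c2cc(C)ccc2-c2ccncc2)CC1` gives 540 nM in an assay for inhibition of cholesterol 24-hydroxylase (Homo sapiens), using NADPH, with stated times of 15 min and 5 min; a lower number here means a stronger inhibitor, a higher number a weaker inhibitor.
Compound 2: `Cc1cccc(C(=O)N2CCC(O)(Cc3ccccc3)CC2)c1-c1ccncc1` gives 130 nM in this assay.

Of the compounds shown here, two have been measured so far. Of these, compound 2 has the lower number in this assay, and the gap to compound 1 is beyond the usual scatter, so compound 2 is the stronger inhibitor of the pair. The two compounds differ in more than one place, so no single structural change can be read from their values.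

Compound 3, `O=C(c1ccccc1-c1ccncc1)N1CCC(O)(Cc2ccccc2)CC1`, has not yet been measured. It differs from compound 2 in one place: hydrogen in place of methyl on an aromatic carbon that sits ortho to a pyridin-4-yl group. For the measured compounds named here, no measured pair shows this change alone, so its effect in this assay is not known from the data. Loss of a single methyl group is often a small change, and a modest weakening is expected rather than a large one, though the direction is uncertain. For compound 3, the expected step is a 1.9-fold higher number from compound 2 to compound 3 (0.28 log units; within the scatter). Compound 3 is estimated at 250 nM, with a range from 90 nM to 700 nM.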

Compound 3, half-maximal inhibitory concentration: 7.9 nM
Beside the measured number, compound 3's estimate is 32-fold (1.50 log units) above it; the measured number lies below the stated range.
By their numbers in this assay, from the lowest: compound 3; then compound 2; then compound 1.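

In this assay, hydrogen in place of methyl on the aromatic carbon ortho to a pyridin-4-yl group gives a 16-fold lower number from compound 2 to compound 3 (1.22 log units; beyond the scatter), a large step well beyond the usual scatter. For the compounds shown here, this is the first pair in which this single change can be read alone, and it shows that this position is highly sensitive: the loss of a methyl group, just one heavy atom, turns compound 2 into a much stronger inhibitor. No measurement is available to explain why so small a change has so large an effect.

Still open, as far as these compounds go, is how other small groups at this position, such as a fluorine, a chlorine or a methoxy group, would compare with hydrogen and methyl, and so whether any group there weakens inhibition or methyl alone does. Also open, from the compounds shown here alone, is whether removing a methyl group gives a step of similar size elsewhere, as in compound 1, whose methyl group stands at a different place on the aromatic ring and which differs from compound 3 in more than that one respect.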